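This account rests on a few compounds, and the source may have more. Where it says the series, first, only, none or still open, it means among the compounds named here.

Compound 2 `CNC(=O)N1CCCc2ccc(NC(=O)c3ccc(-c4ccccn4)cc3)cc21` and compound 1 `CNC(=O)N1CCCc2ccc(NC(=O)c3ccc(-c4ccn(C(C)=O)n4)cc3)cc21` share one core and differ only in the aromatic group attached to it. In a functional assay on MV4-11 cells (Homo sapiens) for antiproliferative activity, with a stated time of 6 days, tested at 1.56 uM (on this read-out lower numbers stand for a weaker effect and higher numbers for a stronger effect at the one concentration tested), compound 1 gives 35.8%, and compound 2 gives 32%. The single measured step, a number 3.8 percentage points lower from compound 1 to compound 2 (within the scatter), lies within the scatter, so on the numbers shown compound 2 cannot be told apart from compound 1: the two stand together, and neither can be called the weaker.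

Compound 3 `CNC(=O)N1CCCc2ccc(NC(=O)c3ccc(-c4cn[nH]c4)cc3)cc21` has not yet been measured. It differs from compound 2 by 1H-pyrazol-4-yl in place of pyridin-2-yl on an aromatic carbon. Among the measured compounds shown here, no measured step swaps pyridin-2-yl for 1H-pyrazol-4-yl, so the only guide is that exchanging one small aromatic ring for another on an aromatic carbon gave a number 3.8 percentage points lower from compound 1 to compound 2 (within the scatter), a change within the scatter. On that guide the step of a number 2 percentage points higher from compound 2 to compound 3 (within the scatter) expected in this assay is small, with no direction beyond the scatter. Compound 3 is therefore estimated at 34% in this assay, with a range from 15% to 55% to allow for the untested new ring.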

Compound 3, a percentage reported as inhibition, at one concentration (the size of the read-out at that concentration, not a potency): 73.5%
The estimate for compound 3 lay 39.5 percentage points below the measured number; the whole stated range lies below it.
By their numbers in this assay, from the lowest: compounds 2 and 1 (each within the scatter of the next); then compound 3.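

In this assay, the aromatic group at this place, para to a large group, proves far from interchangeable: 1H-pyrazol-4-yl in place of pyridin-2-yl gives a number 41.5 percentage points higher from compound 2 to compound 3 (beyond the scatter), and 1H-pyrazol-4-yl in place of 1-acetyl-1H-pyrazol-3-yl gives a number 37.7 percentage points higher from compound 1 to compound 3 (beyond the scatter). The earlier pair differed by no more than the scatter, so the result shows that a change of ring here can have a large effect, and that two different rings sitting close together in the read-out did not mean the position was indifferent to its group. Against pyridin-2-yl, the entering group has a five-membered rather than a six-membered ring, 2 hetero atoms rather than 1, and 1 hydrogen-bond donor rather than 0, and nothing available accounts for the rise.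

The compounds shown cannot separate those features, so it remains open which of them counts; a 1-methyl-1H-pyrazol-4-yl group, with a methyl on the ring nitrogen, or an unsubstituted 1H-pyrazol-3-yl group would help to pull them apart. On these data alone, with a single tested concentration, the data show a stronger effect at that concentration only, and how the compounds compare at other concentrations remains open.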